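The source may report more compounds than this note shows. Statements on the series, on what has been measured and on what is new or still open speak of the compounds shown alone.

In an ADME assay on HEK293 cells (Homo sapiens) for cytotoxicity, read by MTT assay, with a stated time of 72 h (on this read-out higher numbers stand for weaker inhibition and lower numbers for stronger inhibition), compound 1 `O=C(CN1CCN(C(=O)c2ccc(Cl)cc2)CC1)N1CCN(CCCc2c[nH]c3ccccc23)CC1` gives 98200 nM, compound 2 `COc1ccc(C(=O)N2CCN(CC(=O)N3CCN(CCCc4c[nH]c5ccccc45)CC3)CC2)cc1` gives 156000 nM and compound 3 `O=C(CN1CCN(C(=O)c2ccc(Cl)cc2)CC1)N1CCN(CCCc2c[nH]c3ccc(F)cc23)CC1` gives 44500 nM, the lowest number of the three. Compound 4 `O=C(CN1CCN(C(=O)c2ccc(Br)cc2)CC1)N1CCN(CCCc2c[nH]c3ccc(F)cc23)CC1` differs from compound 3 at one place: bromo in place of chloro on an aromatic carbon, with bromo in place of chloro on an aromatic carbon. The closest measured precedent is the replacement of chloro by methoxy at this same place, a 1.6-fold higher number from compound 1 to compound 2 (0.20 log units; within the scatter). The step of fluoro in place of hydrogen, a 2.2-fold lower number from compound 1 to compound 3 (0.34 log units; beyond the scatter), is modest and concerns a different part of the structure, so it bears less directly. Among the compounds with values here, no bromo compound has yet been measured, and no change beyond the scatter is expected. The expected step is a 1.1-fold lower number from compound 3 to compound 4 (0.03 log units; within the scatter). Compound 4 is estimated at 42000 nM, with an expected range from 22000 nM to 80000 nM.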

Compound 4, half-maximal inhibitory concentration: 60500 nM
The estimate for compound 4 lay 1.4-fold (0.16 log units) below the measured number; the range from low to high includes it.
By their numbers in this assay, from the lowest: compounds 3, 4, 1 and 2 (each within the scatter of the next, the first and the last beyond it).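

In this assay, within the data shown here, the earlier compounds had tested chloro at this place only against methoxy, and without the fluoro on the core. Bromo in place of chloro now gives a 1.4-fold higher number from compound 3 to compound 4 (0.13 log units; within the scatter), so with the fluoro present the two halogens on the phenyl carbonyl are not told apart. Like the methoxy step a 1.6-fold higher number from compound 1 to compound 2 (0.20 log units; within the scatter), this replacement stays within the scatter, and nothing measured here offers an explanation.

From the compounds shown here alone, it remains open whether an amine, a carboxylic acid or a nitrile at this place would move the number beyond the scatter. Going by these compounds, it is also open whether bromo would give the same result on the core of compound 1.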